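The compounds below may be only part of what the source reports. "The series", "measured", "known", "first", "only" and "open" are said of these compounds alone.

Measured so far:
- compound 1, `CS(=O)(=O)Nc1ccc2c(c1)S(=O)(=O)N=C(C1=C(O)C3CCCC3N(CCC3CC3)C1=O)N2`: 0.417 h in an in vitro ADME assay on microsomes from liver (Homo sapiens) for metabolic stability; on this read-out higher numbers stand for a longer-lived compound and lower numbers for a shorter-lived compound
- compound 2, `CS(=O)(=O)Nc1ccc2c(c1)S(=O)(=O)N=C(C1=C(O)C3CCCCCCC3N(Cc3ccc(F)cc3)C1=O)N2`: > 1 h in this assay, a limit of the assay rather than a number
- compound 3, `CC(C)(C)CCN1C(=O)C(C2=NS(=O)(=O)c3cc(NS(C)(=O)=O)ccc3N2)=C(O)C2CCCCC21`: 0.267 h in this assay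

Compound 2 sits at the limit of > 1 h in this assay, at which 1 of the 3 values shown sits. Among the two plain numbers, compound 1 has the higher one, but its gap to compound 3 lies within the usual scatter, so the two cannot be told apart. Compound 4, `CS(=O)(=O)Nc1ccc2c(c1)S(=O)(=O)N=C(C1=C(O)C3CCCC3N(Cc3cccc(F)c3)C1=O)N2`, has not yet been measured; it differs from compound 1 by 3-fluorophenyl in place of cyclopropylmethyl on a saturated chain carbon bound to an amide-type nitrogen in a ring. Among the compounds with values here, no measured pair isolates this change. The step from compound 1 to compound 4 is expected to be a modest rise, a 1.4-fold higher number from compound 1 to compound 4 (0.16 log units; within the scatter), within the scatter at its lower end. Compound 4 is therefore estimated at 0.6 h, in a range from 0.25 h to 1.5 h.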

Compound 4, half-life: 0.85 h
Beside the measured number, compound 4's estimate is 1.4-fold (0.15 log units) below it; low and high end bracket the measured number.
By their numbers in this assay, from the lowest: compounds 3 and 1 (each within the scatter of the next); then compound 4. At a limit, above all of these: compound 2.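

In this assay this position now gives its first readable step, with 3-fluorophenyl in place of cyclopropylmethyl: a 2.0-fold higher number from compound 1 to compound 4 (0.31 log units; beyond the scatter). The group on this saturated chain carbon bound to an amide-type nitrogen in a ring can therefore shift the half-life, and an aromatic ring here does not shorten it. Nothing measured here accounts for the step. From the compounds shown here alone, it remains open whether the fluorine or the aromatic ring carries this step. A plain benzyl group or a pyridine ring at this position would help separate the two.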